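Pyrazoline sulfonamides on prostate cancer cells: nitro to methyl

A few compounds are considered here, and "the series" means these few. Any claim that something is new, unique, unknown or untested is made for them only; others in the source may bear on it.

Three pyrazoline sulfonamides have been measured in a functional assay on PC-3 cells (Homo sapiens) for cytotoxicity, read by MTT assay, with a stated time of 48 h; on this read-out higher numbers stand for weaker inhibition and lower numbers for stronger inhibition. Compound 1 `CC1=NN(S(=O)(=O)c2ccc([N+](=O)[O-])cc2)C(c2cc(Br)cc(Br)c2O)C1` gives 50000 nM. Compound 2 `CC1=NN(S(=O)(=O)c2ccc(C)cc2)C(c2cc(Br)cc(Br)c2O)C1` gives 51200 nM. The change between them is methyl in place of nitro on an aromatic carbon, and it made a 1.0-fold higher number from compound 1 to compound 2 (0.01 log units; within the scatter). Compound 3 `O=c1oc2ccccc2cc1C1=NN(S(=O)(=O)c2ccc([N+](=O)[O-])cc2)C(c2ccccc2)C1` gives 46600 nM; the difference between the core of compound 3 and the core of compound 1 is not broken down here. Compound 4 `Cc1ccc(S(=O)(=O)N2N=C(c3cc4ccccc4oc3=O)CC2c2ccccc2)cc1` is still to be measured in this assay. It differs from compound 3 by methyl in place of nitro on an aromatic carbon, the same change that led from compound 1 to compound 2. Because that step was a 1.0-fold higher number from compound 1 to compound 2 (0.01 log units; within the scatter), the step from compound 3 to compound 4 is expected to be of similar size, namely a 1.0-fold higher number from compound 3 to compound 4 (0.00 log units; within the scatter). Compound 4 is therefore estimated at 47000 nM, with a likely range from 23000 nM to 95000 nM.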

Compound 4, half-maximal inhibitory concentration: 48600 nM
Compound 4: the middle estimate sits 1.0-fold (0.01 log units) below what was measured; measured number inside the range.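

In this assay, the change from 4-nitrophenyl to 4-methylphenyl on the core of compound 3 gives a 1.0-fold higher number from compound 3 to compound 4 (0.02 log units; within the scatter). Set beside the earlier step on the core of compound 1, the change carries over to the second core with no difference that can be told from noise: the same change on two cores in this assay, a 1.0-fold higher number (0.01 log units; within the scatter) from compound 1 to compound 2 and a 1.0-fold higher number (0.02 log units; within the scatter) from compound 3 to compound 4, 1.0-fold (0.01 log units) apart, within the scatter of two such steps This shows only that the swap leaves the number within the scatter on these two cores; it does not show that nitro and methyl are interchangeable on any other core, or how a step beyond the scatter would carry over.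

Still open, from the compounds shown here alone, is whether another group on the same aromatic carbon, such as an amine, a carboxylic acid or a methoxy group, would move the number. Also open, going by these compounds, is whether such a group would behave alike on both cores.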